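Swapping the cinnamoyl amide for a sulfonamide

This account rests on a few compounds, and the source may have more. Where it says the series, first, only, none or still open, it means among the compounds named here.

Measured so far:
- compound 1, `CCCN(CC[C@H]1CC[C@H](NC(=O)/C=C/c2ccc(F)cc2)CC1)[C@H]1CCc2nc(N)sc2C1`, 1 nM
- compound 2, `CCCN(CC[C@H]1CC[C@H](NC(=O)/C=C/c2ccc(OC)cc2)CC1)[C@H]1CCc2nc(N)sc2C1`, 6.7 nM
- compound 3, `CCCN(CC[C@H]1CC[C@H](NC(=O)c2ccc(-n3cncn3)cc2)CC1)[C@H]1CCc2nc(N)sc2C1`, 2.4 nM

These three compounds share one core and differ only in the group attached to the amine nitrogen. They were tested in an assay on brain for displacement of a labelled ligand from D(3) dopamine receptor (Rattus norvegicus); a higher number here means a weaker inhibitor, a lower number a stronger inhibitor. Compound 1 gives the lowest number of the three: its nearest neighbour is compound 3 with a 2.4-fold higher number from compound 1 to compound 3 (0.38 log units; beyond the scatter), and the furthest is compound 2 with a 6.7-fold higher number from compound 1 to compound 2 (0.83 log units; beyond the scatter).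

Compound 4, `CCCN(CC[C@H]1CC[C@H](NS(=O)(=O)c2ccc(Cl)nc2)CC1)[C@H]1CCc2nc(N)sc2C1`, has not yet been tested. It differs from compound 1 in one place: (6-chloropyridin-3-yl)sulfonyl in place of (2-(4-fluorophenyl)ethenyl)carbonyl on an amine nitrogen. This change is larger than either of the measured steps, which only exchanged one aromatic substituent or replaced the ethenyl linker with a direct aryl amide. Both of those steps moved the number upward, by modest amounts, so a step of that size or somewhat beyond it is expected here, toward a weaker inhibitor. For compound 4 the expected step is an 8.0-fold higher number from compound 1 to compound 4 (0.90 log units; beyond the scatter). Compound 4 is therefore estimated at 8 nM, with a range from 2 nM to 40 nM.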

Compound 4, inhibition constant: 0.63 nM
Estimate against measurement, compound 4: 13-fold (1.10 log units) above; the whole stated range lies above it.
By their numbers in this assay, from the lowest: compounds 4 and 1 (each within the scatter of the next); then compound 3; then compound 2.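

In this assay, the exchange on the amine nitrogen, which replaces the (2-(4-fluorophenyl)ethenyl)carbonyl with (6-chloropyridin-3-yl)sulfonyl, gives a 1.6-fold lower number from compound 1 to compound 4 (0.20 log units; within the scatter), so the two compounds cannot be told apart. All three earlier compounds carry a carbonyl on this nitrogen, whereas compound 4 shows that a carbonyl is not required here for a number as low as that of compound 1, even though the linking group and the aromatic ring both change at once. Nothing measured here explains why such a large exchange leaves the number within the scatter.

Since the sulfonyl and the chloropyridine entered together, the compounds shown do not separate what each contributes. A sulfonyl carrying a plain phenyl or a methyl, or an amine in place of the chlorine, would begin to pull the two apart.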